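Replacing the Cyclohexyl Group of Compound 2

The source may hold more compounds than are shown below. What is called first, only, known or untested is meant among the compounds shown, and "the series" means these compounds.

Among the compounds with values here, in an ADME assay on S9 fraction from liver (Rattus norvegicus) for metabolic stability, with a stated time of 1 h (on this read-out higher numbers stand for a more stable compound and lower numbers for a less stable compound), compound 2 `NC(=O)c1cnc(NC2CCCCC2)nc1N[C@@H]1CCC[C@H](O)C1` gives 1%, the lower of the two numbers so far, while compound 1 `CC(C)(C)Nc1ncc(C(N)=O)c(N[C@@H]2CCC[C@H](O)C2)n1` gives 98%. Compound 3 `NC(=O)c1cnc(NC23CC(C2)C3)nc1N[C@@H]1CCC[C@H](O)C1` departs from compound 2 on a nitrogen on an aromatic ring, where the cyclohexyl leaves: a group of 5 heavy atoms (5 carbon; 2 four-membered non-aromatic rings of carbon only) in place of a group of 6 heavy atoms (6 carbon; one six-membered non-aromatic ring of carbon only), on a nitrogen on an aromatic ring. Within the data shown here, only one measured step bears on this change, and it is large and beyond the scatter: a number 97 percentage points lower from compound 1 to compound 2 (beyond the scatter). That step concerns the same place, but neither of its groups is the one entering here, so it offers only a rough guide. Compound 2 lies at the bottom of the scale with 1%, so any real change in this assay is expected to be upward, and a large step is expected: a number 69 percentage points higher from compound 2 to compound 3 (beyond the scatter). Compound 3 is estimated at 70%, with an expected range from 35% to 95%.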

Compound 3, percent of the compound remaining: 75%
Beside the measured number, compound 3's estimate is 5 percentage points below it; measured number inside the range.
By their numbers in this assay, from the lowest: compound 2; then compound 3; then compound 1.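

In this assay, the swap on a nitrogen on an aromatic ring gives a number 74 percentage points higher from compound 2 to compound 3 (beyond the scatter), so a carbon ring at this place does not in itself bring the very low number seen with cyclohexyl, something the earlier pair could not separate from the loss of tert-butyl. The new group does not fully match tert-butyl, however, with a number 23 percentage points lower from compound 1 to compound 3 (beyond the scatter), a modest step that is still beyond the scatter. Nothing given here accounts for either step.

Within the data shown here, with only three groups at this place, it remains open whether ring size, ring shape or branching tracks these numbers. A cyclopentyl or cyclobutyl ring, an open chain such as isopropyl, or a ring carrying an oxygen atom, such as tetrahydropyranyl, could help separate these possibilities.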